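The source may hold more compounds than are shown below. What is called first, only, known or untested is meant among the compounds shown, and "the series" means these compounds.

Of the compounds shown here, three built on a shared core have been tested in an in vitro assay on HEK293 cells for displacement of a labelled ligand from adenosine receptor A2b (Homo sapiens); on this read-out lower numbers stand for stronger inhibition and higher numbers for weaker inhibition. Compound 1 `CCCn1c(=O)c2nc(-c3cnn(Cc4cccc(C)c4)c3)[nH]c2n(CCC)c1=O` gives 36 nM, the lowest number of the three. Compound 2 `CC(C)Cn1c(=O)c2nc(-c3cnn(Cc4cccc(C(F)(F)F)c4)c3)[nH]c2n(CC(C)C)c1=O` gives 300 nM, and compound 3 `CCCn1c(=O)c2nc(-c3cc(C)nn3CC)[nH]c2n(CCC)c1=O` gives 2100 nM; both of these numbers lie beyond the scatter above that of compound 1, so compound 1 is the strongest of the measured set.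

Compound 4 `CCCn1c(=O)c2nc(-c3cnn(Cc4c(F)cccc4F)c3)[nH]c2n(CCC)c1=O` has not yet been measured. It differs from compound 1 in one place: 2,6-difluorophenyl in place of 3-methylphenyl on a saturated chain carbon bound to an aromatic nitrogen. Within the data shown here, no measured pair in this set carries a swap of this kind, so the size of the step cannot be read off from a comparable change. A small step is expected, either towards a somewhat higher number or none beyond the scatter. For compound 4 the estimate in this assay is 60 nM, with a range from 15 nM to 250 nM. The expected step from compound 1 to compound 4 is a 1.7-fold higher number from compound 1 to compound 4 (0.22 log units; within the scatter).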

Compound 4, inhibition constant: 390 nM
Compound 4: the middle estimate sits 6.5-fold (0.81 log units) below what was measured; the measured number lies above the stated range.
By their numbers in this assay, from the lowest: compound 1; then compounds 2 and 4 (each within the scatter of the next); then compound 3.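

Among these compounds, until now, no two compounds differed in one place only, so the effect of a change at this position could not be read. Replacing 3-methylbenzyl with 2,6-difluorobenzyl in this assay gives an 11-fold higher number from compound 1 to compound 4 (1.03 log units; beyond the scatter) and this shows that, with everything else held constant, the group carried on this saturated chain carbon strongly affects the read-out. Nothing measured here explains why the number rises.

The change removes a methyl group and adds two fluorine atoms in one step, so these compounds cannot separate the contribution of losing the methyl from that of adding the fluorines. On these data alone, it also remains open how an unsubstituted phenyl, a 3-fluorophenyl or a 3-methoxyphenyl group would behave at this position.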